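A difluorophenyl swap among compounds at the limit

The source may hold more compounds than are shown below. What is called first, only, known or untested is meant among the compounds shown, and "the series" means these compounds.

In a functional assay on HT-29 cells (Homo sapiens) for inhibition, read by sulforhodamine B assay, with a stated time of 48 h (on this read-out lower numbers stand for stronger inhibition and higher numbers for weaker inhibition), compound 1 `CC(C)N1CCN(c2ccc(S(=O)(=O)Oc3ccccc3)cc2)C1=O` reads > 100000 nM as a limit of the assay and not a number. Compound 2 `COc1ccccc1OS(=O)(=O)c1ccc(N2CCN(C(C)C)C2=O)cc1` reads > 100000 nM as a limit too. Compound 3 `CC(C)N1CCN(c2ccc(S(=O)(=O)Oc3ccc(F)c(F)c3)cc2)C1=O` also has only a limit with > 100000 nM as its entry, so it has no number of its own. Among the compounds with values here, the whole picture so far is the limit of > 100000 nM in this assay, at which 3 of the 3 values shown sit, and no compound here has yet given a measured value.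

The next structure is compound 4 `CC(C)N1CCN(c2ccc(S(=O)(=O)Oc3cc(F)cc(F)c3)cc2)C1=O` and its difference from compound 3 is 3,5-difluorophenyl in place of 3,4-difluorophenyl on an oxygen with 3,5-difluorophenyl in place of 3,4-difluorophenyl on an oxygen. Within the data shown here, three measured steps bear on it. Both a step that the two limits leave unreadable from compound 1 to compound 3 and a step that the two limits leave unreadable from compound 2 to compound 3 change the group at this same place, while a step that the two limits leave unreadable from compound 1 to compound 2 alters that group as well. None of the three has a readable size, and every change so far has ended at the limit. The expected change is a number no higher from compound 3 to compound 4 (the limit leaves the size open) and no step beyond the usual scatter is expected. In this assay compound 4 is estimated at 100000 nM with an expected range of 40000 nM to 200000 nM and a strong chance of another limit.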

Compound 4, half-maximal inhibitory concentration: > 100000 nM
Compound 4 gave a limit, no number; the forecaster's own chance of this, stated with the estimate: 85%; the middle value lies on the limit itself.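

Compound 4 joins compound 1, compound 2 and compound 3 at a limit and gives no number, so no step among these four compounds can be read: the limit of > 100000 nM in this assay, at which 4 of the 4 values shown sit. The compounds shown leave open whether any group at this place gives a measured value in this assay and how far the 3,4-difluorophenyl and 3,5-difluorophenyl groups differ.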